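This account rests on a few compounds, and the source may have more. Where it says the series, first, only, none or still open, it means among the compounds named here.

Going by the values given here, compound 2 `CCCCCCCCCCCCCCCC(=O)Nc1nnc(S[C@@H]2O[C@H](CO)[C@H](O)[C@H](O)[C@H]2O)s1` gives 62300 nM in a functional assay on MDA-MB-231 cells (Homo sapiens) for cytotoxicity, read by MTT assay, with a stated time of 24 h (on this read-out higher numbers stand for weaker inhibition and lower numbers for stronger inhibition), the higher of the two numbers so far, though its only neighbour, compound 1 `CCCCCCCCCCCC(=O)Nc1nnc(S[C@@H]2O[C@H](CO)[C@H](O)[C@H](O)[C@H]2O)s1` at 32000 nM, sits within the scatter of it. Compound 3 `CCCCCCCC/C=C\CCCCCCCCCCCC(=O)Nc1nnc(S[C@@H]2O[C@H](CO)[C@H](O)[C@H](O)[C@H]2O)s1` differs from compound 2 by dec-1-en-1-yl in place of butyl on a saturated chain carbon, ten or more bonds along the chain from a carbonyl carbon. Among the compounds with values here, the single step that bears on this is a 1.9-fold higher number from compound 1 to compound 2 (0.29 log units; within the scatter), where the same chain grew and the number stayed within the scatter. Within the data shown here, the new change grows the chain again and brings a double bond, for which no measured pair exists. Compound 3 is therefore expected to show a 1.1-fold higher number from compound 2 to compound 3 (0.05 log units; within the scatter), with an estimate of 70000 nM and a range from 30000 nM to 160000 nM.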

Compound 3, half-maximal inhibitory concentration: 70400 nM
Beside the measured number, compound 3's estimate is 1.0-fold (0.00 log units) below it; the measured number falls inside the stated range.
By their numbers in this assay, from the lowest: compounds 1, 2 and 3 (each within the scatter of the next, the first and the last beyond it).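

In this assay, dec-1-en-1-yl in place of butyl gives a 1.1-fold higher number from compound 2 to compound 3 (0.05 log units; within the scatter), so this first change to carry a double bond stays within the scatter. Only the larger change, dec-1-en-1-yl in place of hydrogen, passes the scatter, and modestly, with a 2.2-fold higher number from compound 1 to compound 3 (0.34 log units; beyond the scatter). No supporting data bear on why these numbers fall as they do.

The longer chain and the double bond enter together here, so their shares cannot be separated. From the compounds shown here alone, how an amine or a carboxylic acid on that saturated chain carbon would read also remains open.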